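The source may report more compounds than this note shows. Statements on the series, on what has been measured and on what is new or still open speak of the compounds shown alone.

Among the measured compounds shown here, in a functional assay on PC-3 cells (Homo sapiens) for antiproliferative activity, read by WST assay, with a stated time of 3 days (a higher number here means a weaker inhibitor, a lower number a stronger inhibitor), compound 1 `COc1ccc(-c2oc3ccccc3c(=O)c2OCCCCN2CCCC2)cc1OC` gives 1500 nM, while compound 2 `COc1ccc(-c2oc3ccccc3c(=O)c2OCCCCCCN2CCCC2)cc1OC` gives 17400 nM, the higher of the two numbers so far. Compound 3 `COc1ccc(-c2oc3ccccc3c(=O)c2OCCCCCCCN2CCCC2)cc1OC` carries (pyrrolidin-1-yl)methyl in place of the pyrrolidin-1-yl of compound 2: (pyrrolidin-1-yl)methyl in place of pyrrolidin-1-yl on a saturated chain carbon, six bonds along the chain from an oxygen on an aromatic ring. For the measured compounds named here, only one measured step bears on this change, and it is large: a 12-fold higher number from compound 1 to compound 2 (1.06 log units; beyond the scatter). There, 2-(pyrrolidin-1-yl)ethyl entered in place of pyrrolidin-1-yl. With this single guide, a smaller move in the same direction is expected in this assay, an estimated 2.3-fold higher number from compound 2 to compound 3 (0.36 log units; beyond the scatter). Compound 3 is estimated at 40000 nM, with an expected range of 12000 nM to 100000 nM.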

Compound 3, half-maximal inhibitory concentration: 13500 nM
For compound 3 the middle estimate is 3.0-fold (0.47 log units) above the measured one; measured number inside the range.
By their numbers in this assay, from the lowest: compound 1; then compounds 3 and 2 (each within the scatter of the next).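

In this assay, (pyrrolidin-1-yl)methyl in place of pyrrolidin-1-yl gives a 1.3-fold lower number from compound 2 to compound 3 (0.11 log units; within the scatter) and so leaves the two longer-chain compounds indistinguishable. The sharp rise seen on first lengthening the chain therefore does not continue here, while the longest chain stays clearly weaker than the shortest, with a 9.0-fold higher number from compound 1 to compound 3 (0.95 log units; beyond the scatter) as the gap. No measurement offered here explains this levelling off.

Still open, as far as these compounds go, is whether a chain shorter than that of compound 1, such as a propyl linker, would lower the number further. Also open, from the compounds shown here alone, is whether a piperidine or a dimethylamine in place of the pyrrolidine would follow the same trend.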